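Para substituent swaps on the benzoyl hydrazide series

A few compounds are considered here, and "the series" means these few. Any claim that something is new, unique, unknown or untested is made for them only; others in the source may bear on it.

Compound 1 `CC(C)(C)N(NC(=O)c1ccccc1I)C(=O)c1ccccc1Cl` gives 1290 nM in an assay on cells for agonist activity at ecdysone receptor (Bombyx mori), read by a luciferase reporter, with a stated time of 24 h; on this read-out higher numbers stand for an effect only at larger amounts of compound and lower numbers for an effect already at smaller amounts. Compound 2 `CC(C)(C)N(NC(=O)c1ccc(F)cc1)C(=O)c1ccccc1Cl` gives 389 nM, and compound 3 `CC(C)(C)N(NC(=O)c1ccc(C#N)cc1)C(=O)c1ccccc1Cl` gives 603 nM. The steps run a 3.3-fold lower number from compound 1 to compound 2 (0.52 log units; beyond the scatter) and a 2.1-fold lower number from compound 1 to compound 3 (0.33 log units; beyond the scatter), both modest, while a 1.6-fold higher number from compound 2 to compound 3 (0.19 log units; within the scatter) stays within the scatter. Within the data shown here, compound 3 thus holds the second highest of the numbers so far: compound 2 sits nearest, within the scatter, and compound 1 lies furthest, beyond it.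

Compound 4 `CCc1ccc(C(=O)NN(C(=O)c2ccccc2Cl)C(C)(C)C)cc1` differs from compound 3 by ethyl in place of cyano on an aromatic carbon. Among the measured compounds shown here, the only step that bears on this is the exchange of one group at the same place, a 1.6-fold higher number from compound 2 to compound 3 (0.19 log units; within the scatter), which was within the scatter; no step tests ethyl itself. On that basis no step beyond the scatter is expected in this assay. The estimated step is a 1.2-fold lower number from compound 3 to compound 4 (0.08 log units; within the scatter). Compound 4 is therefore expected at 500 nM, with a range from 180 nM to 1400 nM.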

Compound 4, half-maximal effective concentration: 5.75 nM
The estimate for compound 4 lay 87-fold (1.94 log units) above the measured number; measured number below the stated range.
By their numbers in this assay, from the lowest: compound 4; then compounds 2 and 3 (each within the scatter of the next); then compound 1.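

At the place para to a large group, the exchange of fluoro for cyano had stayed within the scatter (a 1.6-fold higher number from compound 2 to compound 3 (0.19 log units; within the scatter)), so the position could have seemed tolerant of what it carries; ethyl shows otherwise in this assay, with a 100-fold lower number from compound 3 to compound 4 (2.02 log units; beyond the scatter) and a 68-fold lower number from compound 2 to compound 4 (1.83 log units; beyond the scatter). Against the iodo-bearing compound the same holds, with 4-ethylphenyl giving a 220-fold lower number from compound 1 to compound 4 (2.35 log units; beyond the scatter), a step that the 4-fluorophenyl and 4-cyanophenyl groups do not approach (a 3.3-fold lower number from compound 1 to compound 2 (0.52 log units; beyond the scatter) and a 2.1-fold lower number from compound 1 to compound 3 (0.33 log units; beyond the scatter)). No measurement here accounts for the size of this step.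

Going by these compounds, whether the gain is specific to ethyl or extends to methyl, propyl or a longer chain remains open. Also open, on these data alone, is how a methoxy group or an amine would fare at this place.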